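Sulfanyl chain variation: from compound 3 to compound 4

The compounds below may be only part of what the source reports. "The series", "measured", "known", "first", "only" and "open" are said of these compounds alone.

Values in a functional assay on BGC-823 cells (Homo sapiens) for inhibition, read by MTT assay, with a stated time of 72 h; a lower number here means a stronger inhibitor, a higher number a weaker inhibitor:
compound 1 `CCCSc1nc2nc(C)cc(N3CC[C@@H](C)[C@@H](N(C)c4ncnc5[nH]ccc45)C3)n2n1`: 51200 nM
compound 2 `Cc1cc(N2CC[C@@H](C)[C@@H](N(C)c3ncnc4[nH]ccc34)C2)n2nc(SCC3CCCCC3)nc2n1`: 16300 nM
compound 3 `Cc1cc(N2CC[C@@H](C)[C@@H](N(C)c3ncnc4[nH]ccc34)C2)n2nc(SCc3ccc([N+](=O)[O-])cc3)nc2n1`: 59600 nM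

Compound 3 gives the highest number of the three, but its gap to compound 1 is small: a 1.2-fold higher number from compound 1 to compound 3 (0.07 log units; within the scatter). The gap to compound 2 is larger: a 3.7-fold higher number from compound 2 to compound 3 (0.56 log units; beyond the scatter).

Compound 4 `Cc1cc(N2CC[C@@H](C)[C@@H](N(C)c3ncnc4[nH]ccc34)C2)n2nc(SCCCc3ccccc3)nc2n1` carries the change (phenethyl in place of 4-nitrophenyl on a saturated chain carbon bound to a sulfur). Both steps ending at compound 3 bear on it, since each swaps the group on the saturated chain carbon bound to the sulfur. Compound 2, with cyclohexyl there, gave the lowest number; compound 4 again carries a group with 0 hydrogen-bond acceptors and one six-membered aromatic ring of carbon only. A modest lowering is therefore expected, a 2.4-fold lower number from compound 3 to compound 4 (0.38 log units; beyond the scatter). Compound 4 is estimated at 25000 nM, in the range 9000 nM to 65000 nM.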

Compound 4, half-maximal inhibitory concentration: > 100000 nM
Compound 4 was reported as a limit; the forecaster's own chance of this, stated with the estimate: 5%; middle value at least 4.0-fold (0.60 log units) from the limit.
By their numbers in this assay, from the lowest: compound 2; then compounds 1 and 3 (each within the scatter of the next). At a limit, above all of these: compound 4.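

Compound 4 is reported only as a limit, not a number: the limit of > 100000 nM in this assay, at which 1 of the 4 values shown sits. In this assay, the clear separation is from the cyclohexylmethyl chain, with an at least 6.1-fold higher number from compound 2 to compound 4 (0.78 log units; beyond the scatter), so a terminal ring on this sulfanyl chain does not by itself keep the lower number of compound 2. The other floors, an at least 1.6-fold higher number from compound 3 to compound 4 (0.22 log units; that floor lies within the scatter) and an at least 1.9-fold higher number from compound 1 to compound 4 (0.29 log units; that floor lies within the scatter), do not clear the scatter.

As far as these compounds go, whether the phenyl ring or the chain length drives the step to compound 4 remains open. An unsubstituted benzyl group on the sulfur, or an amine at the chain end, would test this.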